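Trimming tert-butyl to isopropyl in the allyl series

The source may report more compounds than this note shows. Statements on the series, on what has been measured and on what is new or still open speak of the compounds shown alone.

Measured so far:
- compound 1 `C=CCNC(=O)[C@@H](NC(=O)[C@@](O)(CCCN(Cc1ccc(Br)cc1)NC(=O)[C@@H](NC(=O)OC)C(C)(C)C)Cc1ccc(C=C)cc1)C(C)(C)C`: 45 10^-6 cm/s
- compound 2 `C=CCNC(=O)[C@@H](NC(=O)[C@@](O)(CCCN(Cc1ccc(Br)cc1)NC(=O)[C@@H](NC(=O)OC)C(C)(C)C)Cc1ccc(CC=C)cc1)C(C)(C)C`: 44 10^-6 cm/s

For the measured compounds named here, in an ADME assay on Caco-2 cells (Homo sapiens) for permeability (a higher number here means that the compound crosses the layer faster, a lower number that the compound crosses the layer more slowly), compound 2 sits within the scatter of compound 1, the only other measured compound. That single step, a 1.0-fold lower number from compound 1 to compound 2 (0.01 log units; within the scatter), is allyl in place of vinyl on an aromatic carbon. It lies elsewhere in the molecule and offers only an indirect guide.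

Compound 3 `C=CCNC(=O)[C@@H](NC(=O)[C@@](O)(CCCN(Cc1ccc(Br)cc1)NC(=O)[C@@H](NC(=O)OC)C(C)(C)C)Cc1ccc(CC=C)cc1)C(C)C` carries hydrogen in place of methyl on a saturated chain carbon bound to three saturated chain carbons, hydrogen in place of methyl on a saturated chain carbon bound to three saturated chain carbons, turning tert-butyl into isopropyl. Going by the values given here, no measured step covers this change, so nothing beyond the scatter is expected in this assay. The expected step is a 1.1-fold lower number from compound 2 to compound 3 (0.04 log units; within the scatter) in estimate. For compound 3 the estimate is 40 10^-6 cm/s, within an expected range of 22 10^-6 cm/s to 70 10^-6 cm/s for now.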

Compound 3, apparent permeability: 44 10^-6 cm/s
For compound 3 the middle estimate is 1.1-fold (0.04 log units) below the measured one, and the stated range covers the measured number.
By their numbers in this assay, from the lowest: compounds 2, 3 and 1 (each within the scatter of the next).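

Trimming tert-butyl to isopropyl, hydrogen in place of methyl on a saturated chain carbon bound to three saturated chain carbons, gives no change at the digits printed from compound 2 to compound 3 (within the scatter) in this assay. For the compounds shown here, this is the first measured step at this position, and the read-out does not separate the two groups. No measurement bears on the reason for this result.

Still open, from the compounds shown here alone, is whether a smaller methyl or a larger cyclohexyl at this position would stay within the scatter in this assay. Also open, going by these compounds, is whether the same trim of the other tert-butyl, on the methyl carbamate side, would read the same.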